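A ring swap on the way to compound 3

The source may hold more compounds than are shown below. What is called first, only, known or untested is meant among the compounds shown, and "the series" means these compounds.

Measured values in a physicochemical assay for lipophilicity, using the shake flask method, at pH 7.4 (a lower number here means a more polar compound, a higher number a more lipophilic compound), are as follows.
- compound 1 (`CS(=O)(=O)N1CCN([C@H]2CC[C@H](Nc3ncnc4[nH]cc(C5CCOCC5)c34)CC2)CC1`): 1.5
- compound 2 (`COC(=O)N1CCN([C@H]2CC[C@H](Nc3ncnc4[nH]cc(C5CCOCC5)c34)CC2)CC1`): 2

Of these two numbers, compound 2 holds the higher, and its gap to compound 1 lies beyond the scatter. Among the measured compounds shown here, the one measured step is a number 0.50 log units higher from compound 1 to compound 2 (beyond the scatter) and it places methoxycarbonyl in place of methylsulfonyl on an amine nitrogen in a ring.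

Compound 3 (`CN(C)C(=O)C1CCN([C@H]2CC[C@H](Nc3ncnc4[nH]cc(C5CCOCC5)c34)CC2)CC1`) now follows from compound 2, with 4-(dimethylcarbamoyl)piperidin-1-yl in place of 4-(methoxycarbonyl)piperazin-1-yl on a saturated ring carbon. The measured step bears on this change only loosely, since the ring stayed in place there, whereas here the ring itself is replaced. For the measured compounds named here, no measured compound covers such a replacement, so the direction rests on judgement of the structural change alone. A fall somewhat larger than the measured step seems likely, and the expected change is a number 0.80 log units lower from compound 2 to compound 3 (beyond the scatter) in this assay as an estimate with wide uncertainty. Compound 3 is therefore expected at 1.2 (estimated range 0.6 to 1.8).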

Compound 3, distribution coefficient: -0.1
Beside the measured number, compound 3's estimate is 1.30 log units above it; the whole stated range lies above it.
By their numbers in this assay, from the lowest: compound 3; then compound 1; then compound 2.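

Changing the whole group on this saturated ring carbon moves the number in this assay much further than changing only the substituent on the ring nitrogen, which gave a number 0.50 log units higher from compound 1 to compound 2 (beyond the scatter); the ring swap gives a number 2.10 log units lower from compound 2 to compound 3 (beyond the scatter), and a number 1.60 log units lower from compound 1 to compound 3 (beyond the scatter). Compound 3 therefore stands lowest of the three, even though the entering 4-(dimethylcarbamoyl)piperidin-1-yl has more carbon atoms, fewer oxygen atoms and fewer hydrogen-bond acceptors than the 4-(methoxycarbonyl)piperazin-1-yl leaving compound 2, so these counts alone give no guide to the direction at this position. Nothing available here accounts for the size of the fall.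

The step from compound 2 to compound 3 changes the ring and its substituent together, so the compounds shown cannot say how much of the fall belongs to either. A 4-(dimethylcarbamoyl)piperazin-1-yl group or a 4-(methoxycarbonyl)piperidin-1-yl group would divide the two changes, while a piperidine ring bearing a carboxylic acid or a primary amine would show how far the number moves with other substituents on the same ring.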